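This account rests on a few compounds, and the source may have more. Where it says the series, first, only, none or still open, it means among the compounds named here.

The study measures three compounds in an ADME assay on MT2 cells (Homo sapiens) for cytotoxicity, read by XTT assay, with a stated time of 4 days; on this read-out lower numbers stand for higher toxicity in this test and higher numbers for lower toxicity in this test. Compound 1 `Cc1nc2c(c(-c3cc(F)c4c(c3C)CCCO4)c1[C@H](OC(C)(C)C)C(=O)O)CN(CCCc1cccc(F)c1)CC2` is the starting point. In this assay compound 1 gives > 40000 nM, which is a limit of the assay rather than a number. Compound 2 `Cc1ccc(-c2c3c(nc(C)c2[C@H](OC(C)(C)C)C(=O)O)CCN(C(=O)NCc2ccccc2)C3)cc1` is also measured, and in this assay compound 2 gives > 40000 nM, again a limit. Compound 3 `COC(=O)N1CCc2nc(C)c(C(OC(C)(C)C)C(=O)O)c(-c3ccc(C)cc3)c2C1` follows suit: in this assay compound 3 gives > 40000 nM, a limit as well. Compound 1 therefore stands where every measured value sits, at the limit of > 40000 nM in this assay, at which 3 of the 3 values shown sit, and no pair of these compounds differs in a single place, so no measured step is available to lean on.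

Compound 4 `Cc1ccccc1CCCN1CCc2nc(C)c([C@H](OC(C)(C)C)C(=O)O)c(-c3cc(F)c4c(c3C)CCCO4)c2C1` has not yet been measured. It differs from compound 1 in one place: 2-methylphenyl in place of 3-fluorophenyl on a saturated chain carbon, three bonds along the chain from an amine nitrogen in a ring. With all three measured values resting at the same limit and no step of any size shown between them, there is no ground for expecting this change to move the read-out in either direction. The step from compound 1 to compound 4 is expected to be none beyond the scatter, that is a number no higher from compound 1 to compound 4 (the limit leaves the size open). Compound 4 is accordingly expected to give about 40000 nM in this assay, within 20000 nM to 80000 nM, most likely reported again only as a limit.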

Compound 4, half-maximal cytotoxic concentration: > 40000 nM
Compound 4 ended at the assay's limit; the forecaster's own chance of this, stated with the estimate: 85%; the middle value lies on the limit itself.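

In this assay compound 4 gives > 40000 nM, which is a limit of the assay and not a number. Compound 1 also rests at a limit, so no step can be read from compound 1 to compound 4. The compounds shown leave open how their true values compare, since all remain unresolved: the limit of > 40000 nM in this assay, at which 4 of the 4 values shown sit.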